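Dibenzylhydrazones of aryl aldehydes: methoxy on the aryl ring

The compounds below may be only part of what the source reports. "The series", "measured", "known", "first", "only" and "open" are said of these compounds alone.

Two measured compounds frame the series. Compound 1 `C(=N/N(Cc1ccccc1)Cc1ccccc1)\c1ccccc1` gives 1500 nM in an assay on liver (Sus scrofa) for inhibition of glucose-6-phosphatase catalytic subunit 1 (Homo sapiens), using microsomes; a higher number here means a weaker inhibitor, a lower number a stronger inhibitor. Compound 2 `c1ccc(CN(Cc2ccccc2)/N=C2\CCCc3ccccc32)cc1` gives 25000 nM in this assay, a weaker result than compound 1 by a margin that lies beyond the usual scatter, so compound 1 stands as the stronger of the two numbers seen so far and is the better reference for the next step.

Compound 3 `COc1ccccc1/C=N/N(Cc1ccccc1)Cc1ccccc1` has not yet been measured. It keeps the core of compound 1 and differs from it in one place: methoxy in place of hydrogen on an aromatic carbon. Going by the values given here, no step between two measured compounds shows what this change does; compound 2 is altered elsewhere and does not inform it.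

Among the compounds with values here, for a single methoxy on the aromatic ring, with no precedent, the expectation is a step from compound 1 to compound 3 in this assay of a 1.2-fold lower number from compound 1 to compound 3 (0.06 log units; within the scatter), that is, no change beyond the scatter in either direction. Compound 3 is therefore expected at 1300 nM, with a range from 400 nM to 4500 nM.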

Compound 3, half-maximal inhibitory concentration: > 100000 nM
Compound 3: a limit, no number; the forecaster's own chance of this, stated with the estimate: 3%; middle value at least 76-fold (1.88 log units) away from the limit.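

In this assay, the aromatic carbon ortho to a large group does not accept methoxy in place of hydrogen without a steep cost, since the change gives an at least 66-fold higher number from compound 1 to compound 3 (1.82 log units; beyond the scatter). Compound 3 stands as a limit of the assay and not a number: the limit of > 100000 nM in this assay, at which 1 of the 3 values shown sits. So a group of only 2 heavy atoms, placed at this one carbon, is enough to take the core of compound 1 from a measured number to the limit, something compound 2, altered elsewhere, could not show.

The compounds shown do not separate the effect of the position from that of the group, so it remains open whether a fluorine, a methyl or a hydroxyl on this same carbon would behave as methoxy does, and whether methoxy on another carbon of the ring would do the same. Going by these compounds alone, with only this one step at the position, no cause for its size can be assigned, and the true size of the step stays unknown beyond what the limit allows.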